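The source may hold more compounds than are shown below. What is called first, only, known or untested is meant among the compounds shown, and "the series" means these compounds.

Three compounds built on one shared core have been examined in a functional assay on MCF7 cells (Homo sapiens) for antiproliferative activity, read by MTT assay, with a stated time of 48 h; a higher number here means a weaker inhibitor, a lower number a stronger inhibitor. Compound 1 `N#CC1=C(N)Oc2c(c3nc4ccccc4nc3c3ccccc23)C12C(=O)N(Cc1cnnn1-c1ccccc1Br)c1ccccc12` gives only the limit of this assay, > 50000 nM. Compound 2 `CCOc1ccc(-n2nncc2CN2C(=O)C3(C(C#N)=C(N)Oc4c3c3nc5ccccc5nc3c3ccccc43)c3ccccc32)cc1` likewise gives only the limit of this assay, > 50000 nM. Compound 3 `N#CC1=C(N)Oc2c(c3nc4ccccc4nc3c3ccccc23)C12C(=O)N(Cc1cnnn1-c1cccc(S(N)(=O)=O)c1)c1ccccc12` yields a number in this assay, 42500 nM. Compound 2 thus stands at the limit of > 50000 nM in this assay, at which 2 of the 3 values shown sit, so its true value is not known, only a floor. Compound 4 `Cc1ccc(Cl)cc1-n1nncc1CN1C(=O)C2(C(C#N)=C(N)Oc3c2c2nc4ccccc4nc2c2ccccc32)c2ccccc21` has not yet been measured; it differs from compound 2 in one place: 5-chloro-2-methylphenyl in place of 4-ethoxyphenyl on an aromatic nitrogen. The measured steps that swap the group at this same position are an at least 1.1-fold lower number from compound 1 to compound 3 (0.07 log units; that floor lies within the scatter) and an at least 1.1-fold lower number from compound 2 to compound 3 (0.07 log units; that floor lies within the scatter), both mere floors within the scatter, while a step that the two limits leave unreadable from compound 1 to compound 2 cannot be read. None of them shows a gain beyond the scatter, so the expected step is a number no higher from compound 2 to compound 4 (the limit leaves the size open), with no real movement. Compound 4 is therefore estimated at about 50000 nM in this assay, between 25000 nM and 100000 nM, and is expected most likely to appear again as a limit rather than a number.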

Compound 4, half-maximal inhibitory concentration: > 50000 nM
Compound 4 was reported as a limit; the forecaster's own chance of this, stated with the estimate: 75%; the middle value lies on the limit itself.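

In this assay, compound 4 is also reported only as a limit, so a phenyl ring carrying both chlorine and methyl joins 2-bromophenyl and 4-ethoxyphenyl in giving no measured number at this position. Within the data shown here, the one readable comparison is an at least 1.1-fold higher number from compound 3 to compound 4 (0.07 log units; that floor lies within the scatter), so the new group cannot be separated from the 3-sulfamoylphenyl group of compound 3, while the steps linking compound 1, compound 2 and compound 4 cannot be read, since both ends are limits. Varied substitution on the phenyl ring has thus still not produced a clear gain, and compound 3 alone gives a number: the limit of > 50000 nM in this assay, at which 3 of the 4 values shown sit.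

Every group shown here is a substituted phenyl ring. As far as these compounds go, whether a carboxylic acid on that ring, or a plain alkyl chain or an amine-bearing chain in its place, would give a number clearly under the limit remains open.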